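Working notes: phenoxy in place of phenyl, compound 3

This account rests on a few compounds, and the source may have more. Where it says the series, first, only, none or still open, it means among the compounds named here.

Values so far in a functional assay on PANC-1 cells (Homo sapiens) for inhibition, read by XTT assay, with a stated time of 72 h (on this read-out lower numbers stand for stronger inhibition and higher numbers for weaker inhibition), are these:
Compound 1 `CC(C)(C)OC(=O)N1CCC[C@H]1COCCCCCC/C=C/c1ccc(Oc2ccccc2)cc1` gives 63300 nM as a measured number
Compound 2 `Cc1ccc([S+]([O-])N2CCC[C@H]2COCCCCCC/C=C/c2ccc(-c3ccccc3)cc2)cc1` gives >= 100000 nM as a limit

Compound 2 has no measured number, and its entry of >= 100000 nM is a limit of the assay. Compound 3 `Cc1ccc([S+]([O-])N2CCC[C@H]2COCCCCCC/C=C/c2ccc(Oc3ccccc3)cc2)cc1` changes compound 2 at one place, with phenoxy in place of phenyl on an aromatic carbon, para to a large group (phenoxy in place of phenyl on an aromatic carbon). The entering phenoxy also stands in compound 1, which gives 63300 nM in this assay as a real reading, so some measurable inhibition is expected. The expected at least 1.6-fold lower number from compound 2 to compound 3 (0.22 log units; that floor lies within the scatter) is modest and toward stronger inhibition, and another limit reading remains possible. Compound 3 is estimated at 60000 nM (range 25000 nM to 100000 nM).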

Compound 3, half-maximal inhibitory concentration: 60000 nM
The estimate for compound 3 equals the measured number at the digits printed, within the range that was stated.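

In this assay, phenoxy in place of phenyl on an aromatic carbon, para to a large group, gives an at least 1.6-fold lower number from compound 2 to compound 3 (0.22 log units; that floor lies within the scatter), so this change is not separated from the scatter. Compound 2 stands at a limit and not at a number, which leaves the true size of this step unread: the limit of >= 100000 nM in this assay, at which 1 of the 3 values shown sits.

With phenoxy held in place, exchanging the group on the amine nitrogen in a ring gives a 1.1-fold lower number from compound 1 to compound 3 (0.02 log units; within the scatter), so this pair shows no separable difference between the two nitrogen groups.

Still open, on these data alone, is whether any group at the aromatic position can move the reading clearly, for instance methoxy or benzyloxy in place of phenoxy. Also open, as far as these compounds go, is how a free amine on the ring nitrogen, or a shorter chain, would read in this assay.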